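Ring nitrogen substituent swap on a fused bicyclic core

A few compounds are considered here, and "the series" means these few. Any claim that something is new, unique, unknown or untested is made for them only; others in the source may bear on it.

The compounds were tested in a functional assay on MCF7 cells (Homo sapiens) for antiproliferative activity, read by MTT assay, with a stated time of 72 h; a lower number here means a stronger inhibitor, a higher number a weaker inhibitor.
Compound 1, `COc1cccc(N2C(=O)COc3ccc(-c4cnc(Cl)c(NS(=O)(=O)c5ccc(F)cc5)c4)cc32)c1`: > 40000 nM, which is a limit of the assay and not a number.
Compound 2, `CC(C)N1C(=O)COc2ccc(-c3cnc(Cl)c(NS(=O)(=O)c4ccc(F)cc4)c3)cc21`: 26600 nM.
Compound 3, `COc1cccc(N2C(=O)COc3ccc(-c4cccc(NS(=O)(=O)c5ccc(F)cc5)c4)cc32)c1`: > 40000 nM, again a limit of the assay rather than a number.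

Two of the three measured values thus sit at the limit of > 40000 nM in this assay, at which 2 of the 3 values shown sit. For the measured compounds named here, the one counted change among the measured compounds is isopropyl in place of 3-methoxyphenyl on an amide-type nitrogen in a ring, and it produced an at least 1.5-fold lower number from compound 1 to compound 2 (0.17 log units; that floor lies within the scatter) in this assay. Compound 4, `CC(C)N1C(=O)COc2ccc(-c3cccc(NS(=O)(=O)c4ccc(F)cc4)c3)cc21`, has not yet been measured; it arises from compound 3 by the same change, (isopropyl in place of 3-methoxyphenyl on an amide-type nitrogen in a ring), made on the same place of the ring. How the core of compound 3 differs from that of compound 1 is not broken down here.

Going by the values given here, compound 4 is expected to show an at least 1.3-fold lower number from compound 3 to compound 4 (0.12 log units; that floor lies within the scatter) in this assay, a step of about the size seen from compound 1 to compound 2, because an at least 1.5-fold lower number from compound 1 to compound 2 (0.17 log units; that floor lies within the scatter) is the only measured guide. The estimate for compound 4 is therefore 30000 nM, with the range 12000 nM to 40000 nM.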

Compound 4, half-maximal inhibitory concentration: 26000 nM
For compound 4 the middle estimate is 1.2-fold (0.06 log units) above the measured one; the measured number falls inside the stated range.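

Carried to the core of compound 3, the swap of 3-methoxyphenyl for isopropyl on the amide-type nitrogen in a ring gave, in this assay, an at least 1.5-fold lower number from compound 3 to compound 4 (0.18 log units; that floor lies within the scatter). As far as these compounds go, compound 3 gives > 40000 nM, which is a limit of the assay and not a number, so this step is only a floor, and its true size remains unknown. The change thus points the same way on both cores, but neither step is shown to lie beyond the scatter, and no equal size of effect is shown: the same change on two cores in this assay, an at least 1.5-fold lower number (0.17 log units; that floor lies within the scatter) from compound 1 to compound 2 and an at least 1.5-fold lower number (0.18 log units; that floor lies within the scatter) from compound 3 to compound 4; the limit leaves it open whether they differ.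

Neither member of either pair gives a strong result in this assay, and the limit restricts what can be read from this set: the limit of > 40000 nM in this assay, at which 2 of the 4 values shown sit. The compounds shown leave open how an amine, a carboxylic acid or a longer chain on that nitrogen would read in this assay, and whether any such group would give a number well clear of the limit on either core.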